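Ring Swap on the Alkyne Arm of Compound 2

This account rests on a few compounds, and the source may have more. Where it says the series, first, only, none or still open, it means among the compounds named here.

Measured so far:
compound 1 `C#Cc1cc(C#Cc2ccc3ncn(-c4ccnc(N)n4)c3c2)ccn1` – 31600 nM
compound 2 `C#Cc1ncc(C#Cc2ccc3ncn(-c4ccnc(N)n4)c3c2)cn1` – 79400 nM

In an assay on Sf9 cells for inhibition of mitogen-activated protein kinase kinase kinase 14 variant S549D (Homo sapiens), with a stated time of 30 min, in the presence of a further agent that is not named here (on this read-out lower numbers stand for stronger inhibition and higher numbers for weaker inhibition), compound 2 gives the highest of the two numbers; its nearest neighbour is compound 1, and the step of a 2.5-fold higher number from compound 1 to compound 2 (0.40 log units; beyond the scatter) lies beyond the scatter. Compound 3 `C#Cc1cnc(C#Cc2ccc3ncn(-c4ccnc(N)n4)c3c2)nc1` differs from compound 2 only in how the same atoms are joined: a group of 8 heavy atoms (6 carbon, 2 nitrogen; one six-membered aromatic ring with 2 hetero atoms) in place of a group of 8 heavy atoms (6 carbon, 2 nitrogen; one six-membered aromatic ring with 2 hetero atoms), on a triple-bonded carbon. Among the compounds with values here, no measured step bears directly on this rearrangement; the only measured step, a 2.5-fold higher number from compound 1 to compound 2 (0.40 log units; beyond the scatter), concerns a different exchange at the same triple-bonded carbon and was modest. With nothing to suggest otherwise, compound 3 is expected to sit close to compound 2, with the step of a 1.3-fold lower number from compound 2 to compound 3 (0.10 log units; within the scatter) not expected to exceed the scatter. The estimate for compound 3 in this assay is 63000 nM, with a range from 25000 nM to 160000 nM.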

Compound 3, half-maximal inhibitory concentration: 25100 nM
Compound 3: middle estimate off by 2.5-fold (0.40 log units), on the high side; low and high end bracket the measured number.
By their numbers in this assay, from the lowest: compounds 3 and 1 (each within the scatter of the next); then compound 2.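

Joining the same atoms differently is not a neutral change at this triple-bonded carbon: in this assay the rearrangement gives a 3.2-fold lower number from compound 2 to compound 3 (0.50 log units; beyond the scatter), a step as large as any seen so far in this short series. A ring with 2 hetero atoms is therefore not tied to the higher number, since a 1.3-fold lower number from compound 1 to compound 3 (0.10 log units; within the scatter) separates that ring from the one with 1 hetero atom only when the atoms are joined as in compound 2. No measurement offered here accounts for why the arrangement of the ring atoms matters.

The compounds shown leave open how a plain phenyl ring, with no hetero atom, would read on this triple-bonded carbon. They also leave open whether a nitrile or a methoxy group could stand in place of the outer triple bond on any of these rings.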